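Chain Extension and Chlorine on an Amide Side Chain

The compounds below may be only part of what the source reports. "The series", "measured", "known", "first", "only" and "open" are said of these compounds alone.

In an assay on mitochondria (strain Sprague-Dawley) for inhibition of Amine oxidase [flavin-containing] B (Rattus norvegicus), read by fluorescence and Amplex Red, with stated times of 30 min and 45 min (on this read-out higher numbers stand for weaker inhibition and lower numbers for stronger inhibition), compound 1 `O=C(CCc1ccccc1)Nc1nc2ccccc2c(=O)s1` gives 42.7 nM, the lower of the two numbers recorded. Compound 3 `O=C(COc1cccc(Cl)c1)Nc1nc2ccccc2c(=O)s1` gives 661 nM in this assay, a gap beyond the usual scatter. Compound 2 `O=C(Nc1nc2ccccc2c(=O)s1)c1ccccc1` gives only the limit > 10000 nM, which is a limit of this assay and not a number. Compound 4 `O=C(CCCc1cccc(Cl)c1)Nc1nc2ccccc2c(=O)s1` has not yet been measured; it differs from compound 1 by 3-chlorobenzyl in place of phenyl on a saturated chain carbon, two bonds along the chain from a carbonyl carbon. Going by the values given here, no measured pair here shows that exact change, so the direction rests on expectation alone. Compound 4 is expected to sit close to compound 1, with a step of a 1.9-fold higher number from compound 1 to compound 4 (0.27 log units; within the scatter) judged likely to stay within or just beyond the scatter. The estimate for compound 4 is 80 nM, between 20 nM and 400 nM.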

Compound 4, half-maximal inhibitory concentration: 6880 nM
Compound 4: the middle estimate sits 86-fold (1.93 log units) below what was measured; the whole stated range lies below it.
By their numbers in this assay, from the lowest: compound 1; then compound 3; then compound 4. At a limit, above all of these: compound 2.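

In this assay, 3-chlorobenzyl in place of phenyl on a saturated chain carbon, two bonds along the chain from a carbonyl carbon, gives a 160-fold higher number from compound 1 to compound 4 (2.21 log units; beyond the scatter). Going by these compounds alone, this is the first single-place change, and it shows that inhibition depends strongly on what sits at this place. Compound 2 alone remains at a limit of the assay, which is not a number: the limit of > 10000 nM in this assay, at which 1 of the 4 values shown sits.

The step combines a longer chain with a chlorine, and the compounds shown do not separate the two. As far as these compounds go, whether an unsubstituted benzyl or a 4-chlorobenzyl at this place would bring the same loss remains open.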